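Benzimidazole ether in place of benzoxazole thioether

The source may hold more compounds than are shown below. What is called first, only, known or untested is meant among the compounds shown, and "the series" means these compounds.

Compound 3 `CC(C)[C@H](NC(=O)COc1cccc2ccccc12)C(=O)N[C@@H](CC(=O)O)C(=O)CSc1nc2ccccc2o1` carries a ((1,3-benzoxazol-2-yl)sulfanyl)methyl group on the shared core, at a saturated chain carbon bound to a carbonyl carbon. In a functional assay on Jurkat cells (Homo sapiens) for inhibition (a lower number here means a stronger inhibitor, a higher number a weaker inhibitor), compound 3 gives only the limit > 200000 nM, not a number. The two other measured compounds are no different in kind. Compound 1 `CC(C)[C@H](NC(=O)COc1cccc2ccccc12)C(=O)N[C@@H](CC(=O)O)C(=O)CSC1=NCCS1` gives the limit > 200000 nM in this assay. Compound 2 `CC(C)[C@H](NC(=O)COc1cccc2ccccc12)C(=O)N[C@@H](CC(=O)O)C(=O)CSc1nc(-c2ccccc2)cs1` gives the limit > 200000 nM in this assay. Because all three values sit at the limit of > 200000 nM in this assay, at which 3 of the 3 values shown sit, the steps a step that the two limits leave unreadable from compound 1 to compound 2, a step that the two limits leave unreadable from compound 1 to compound 3 and a step that the two limits leave unreadable from compound 2 to compound 3 cannot be sized in either direction. Compound 4 `CC(C)[C@H](NC(=O)COc1cccc2ccccc12)C(=O)N[C@@H](CC(=O)O)C(=O)COc1nc2ccccc2[nH]1` differs from compound 3 by (1H-benzimidazol-2-yl)oxy in place of (1,3-benzoxazol-2-yl)sulfanyl on a saturated chain carbon bound to a carbonyl carbon. None of the three measured steps is readable, so none of them gives a direction or a size for this step, and there is nothing in the set that points to a stronger inhibitor. Compound 4 is therefore expected to stay at the limit as well, and the step from compound 3 to compound 4 in this assay is estimated as a number no higher from compound 3 to compound 4 (the limit leaves the size open). For compound 4 in this assay the estimate is 200000 nM, with a range from 40000 nM to 1000000 nM.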

Compound 4, half-maximal inhibitory concentration: > 200000 nM
Compound 4: a limit, no number; the forecaster's own chance of this, stated with the estimate: 80%; the middle value sits exactly at the limit.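

Compound 4 also gives only a limit, not a number, so none of the steps from compound 1, compound 2 or compound 3 to compound 4 can be read in this assay: the limit of > 200000 nM in this assay, at which 4 of the 4 values shown sit. The compounds shown leave open how these four groups on the shared core rank against one another, and whether any group at that place would give a number.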